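Chloro for fluoro on the phenoxy ring: clearance outlook

A few compounds are considered here, and "the series" means these few. Any claim that something is new, unique, unknown or untested is made for them only; others in the source may bear on it.

Compound 1 `O=S(=O)(CC1CC1)c1nnc(-c2cc(F)c(-c3cnc(Oc4ccc(F)cc4F)c(Cl)c3)cc2F)[nH]1` in an ADME assay on microsomes from liver (Rattus norvegicus) for metabolic stability (on this read-out lower numbers stand for slow clearance and higher numbers for fast clearance), gives 22 uL/min, at the low end of the three numbers in hand. Compound 3 `CC(C)COc1ncc(-c2cc(F)c(-c3nnc(S(C)(=O)=O)[nH]3)cc2F)cc1Cl` gives 23 uL/min, which is within the scatter of compound 1. Compound 2 `CC(C)COc1ncc(-c2cc(F)c(-c3nnc(S(=O)(=O)C4CCC4)[nH]3)cc2F)cc1Cl` gives 62 uL/min, beyond the scatter above the other two. Among the measured compounds shown here, the one single-point step measured so far, a 2.7-fold lower number from compound 2 to compound 3 (0.43 log units; beyond the scatter), concerns the sulfonyl substituent and not the aryloxy ring.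

Compound 4 `O=S(=O)(CC1CC1)c1nnc(-c2cc(F)c(-c3cnc(Oc4ccc(F)cc4Cl)c(Cl)c3)cc2F)[nH]1` differs from compound 1 by chloro in place of fluoro on an aromatic carbon. For the measured compounds named here, no measured pair carries this change, so nothing in the set bears on it directly; the step of a 2.7-fold lower number from compound 2 to compound 3 (0.43 log units; beyond the scatter) serves only as a gauge of how large a single-atom swap has moved this assay here. The expectation in this assay is therefore no step beyond the scatter, with at most a small drift toward faster clearance; the estimated step is a 1.3-fold higher number from compound 1 to compound 4 (0.10 log units; within the scatter). The value expected for compound 4 is 28 uL/min, with a range from 14 uL/min to 56 uL/min.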

Compound 4, intrinsic clearance in a liver preparation (reported as CLH), per the amount of preparation that the assay uses: 53 uL/min
The estimate for compound 4 lay 1.9-fold (0.28 log units) below the measured number; the range from low to high includes it.
By their numbers in this assay, from the lowest: compounds 1 and 3 (each within the scatter of the next); then compounds 4 and 2 (each within the scatter of the next).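

In this assay, the change from 2,4-difluorophenoxy to 2-chloro-4-fluorophenoxy gives a 2.4-fold higher number from compound 1 to compound 4 (0.38 log units; beyond the scatter). Among the compounds shown here, this is the first measured step on the aryloxy ring, and it shows that a single halogen swap on an aromatic carbon ortho to a large group can move this read-out beyond the scatter, so the sulfonyl substituent is no longer the only place with a measured effect. Nothing in hand accounts for the higher number at this position.

Open, as far as these compounds go, is how the read-out responds to other groups at this place, such as a methyl, a methoxy or a nitrile. Also open, from the compounds shown here alone, is whether the step from fluoro to chloro keeps its size with a methyl or a cyclobutyl on the sulfonyl sulfur.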